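Aryl swap on the flavone core: compound 3 to compound 4

The source may report more compounds than this note shows. Statements on the series, on what has been measured and on what is new or still open speak of the compounds shown alone.

Three members of the series carry a six-carbon chain from the ring oxygen to a basic amine. In an assay on isolated protein (Cavia porcellus) with Sigma non-opioid intracellular receptor 1 (Homo sapiens) as the target, read by radioligand binding (a higher number here means a weaker inhibitor, a lower number a stronger inhibitor), compound 1 `CN(C)CCCCCCCOc1ccc2oc(-c3ccccc3)cc(=O)c2c1` gives 188 nM, and compound 2 `CCOC(=O)C1CCN(CCCCCCOc2ccc3oc(-c4ccccc4)cc(=O)c3c2)CC1` gives 102 nM; the step of a 1.8-fold lower number from compound 1 to compound 2 (0.27 log units; within the scatter). Compound 3 `O=c1cc(-c2cccs2)oc2ccc(OCCCCCCN3CCC(O)CC3)cc12` gives 232 nM; its gap to compound 1 lies within the scatter, while compound 2 gives a lower number than compound 3, beyond the scatter. Compound 4 `COc1ccc(-c2cc(=O)c3cc(OCCCCCCN4CCC(O)CC4)ccc3o2)cc1` differs from compound 3 only in 4-methoxyphenyl in place of thiophen-2-yl on an aromatic carbon. Among the compounds with values here, no measured step touches this position: the single measured step concerns the amine end of the chain. No change beyond the scatter is therefore expected; the step of a 1.3-fold lower number from compound 3 to compound 4 (0.11 log units; within the scatter) is an estimate without precedent here. Compound 4 is expected to give about 180 nM, between 70 nM and 460 nM.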

Compound 4, half-maximal inhibitory concentration: 332 nM
For compound 4 the middle estimate is 1.8-fold (0.27 log units) below the measured one; the range from low to high includes it.
By their numbers in this assay, from the lowest: compounds 2, 1, 3 and 4 (each within the scatter of the next, the first and the last beyond it).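

Within the data shown here, this is the first measured change at this position, on the aromatic carbon next to the ring oxygen. In this assay, 4-methoxyphenyl in place of thiophen-2-yl gives a 1.4-fold higher number from compound 3 to compound 4 (0.16 log units; within the scatter), so exchanging a five-membered aromatic ring for a larger six-membered one leaves the number within the scatter. No evidence on hand bears on this result.

Still open, as far as these compounds go, is whether a pyridin-3-yl or 4-fluorophenyl group here would also stay within the scatter of compound 3. Also open, from the compounds shown here alone, is whether the 4-(ethoxycarbonyl)piperidin-1-yl end of compound 2 would behave alike with either of these two aryl groups.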